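The compounds below may be only part of what the source reports. "The series", "measured", "known", "first", "only" and "open" are said of these compounds alone.

Measured so far:
- compound 1 `COc1cccc(CNC(=O)N2C(=O)c3ccccc3S2(=O)=O)c1`: 0.523 h
- compound 2 `O=C(NCc1ccccc1Cl)N1C(=O)c2ccccc2S1(=O)=O`: 0.42 h
- compound 3 `Cc1ccccc1CNC(=O)N1C(=O)c2ccccc2S1(=O)=O`: 0.792 h

These compounds share one core and differ in the aromatic group on a saturated chain carbon bound to an amide-type nitrogen. In a physicochemical assay for pharmacokinetics (a lower number here means that the compound disappears faster, a higher number that the compound lasts longer), compound 3 gives 0.792 h, which lies within the scatter of both other compounds, so the three cannot be ranked.

Compound 4 `O=C(NCc1cccs1)N1C(=O)c2ccccc2S1(=O)=O` has not been measured. In it, thiophen-2-yl takes the place of 2-methylphenyl at that same place: thiophen-2-yl in place of 2-methylphenyl on a saturated chain carbon bound to an amide-type nitrogen.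

The closest evidence comes from earlier swaps of this group: a 1.2-fold lower number from compound 1 to compound 2 (0.10 log units; within the scatter), a 1.5-fold higher number from compound 1 to compound 3 (0.18 log units; within the scatter) and a 1.9-fold higher number from compound 2 to compound 3 (0.28 log units; within the scatter). All three are small, but none tests a five-membered aromatic ring. No step beyond the scatter is therefore expected, and the data give no firm direction.

The estimate draws on all three measured values, not on compound 3 alone. Compound 4 is expected at 0.55 h, with an estimated range of 0.32 h to 0.95 h. This expectation amounts to a 1.4-fold lower number from compound 3 to compound 4 (0.16 log units; within the scatter).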

Compound 4, half-life: 0.365 h
Estimate against measurement, compound 4: 1.5-fold (0.18 log units) above; the measured number falls inside the stated range.
By their numbers in this assay, from the lowest: compounds 4, 2, 1 and 3 (each within the scatter of the next, the first and the last beyond it).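

In this assay, this position now shows its first step beyond the scatter (a 2.2-fold lower number from compound 3 to compound 4 (0.34 log units; beyond the scatter)), so changing the aromatic group on a saturated chain carbon bound to an amide-type nitrogen can shift the half-life, though only modestly. Thiophen-2-yl stands apart from 2-methylphenyl alone, as the other two steps stay within the scatter (a 1.2-fold lower number from compound 2 to compound 4 (0.06 log units; within the scatter); a 1.4-fold lower number from compound 1 to compound 4 (0.16 log units; within the scatter)). Within the data shown here, nothing available explains the one step beyond the scatter.

From the compounds shown here alone, it remains open whether the step from compound 3 to compound 4 reflects the five-membered ring itself or the loss of the methyl, a question that an unsubstituted phenyl or a furan-2-yl group at this place could help to settle. Going by these compounds, how an amine, a carboxylic acid or a longer chain would behave there also remains open.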